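Swapping ethoxy for fluoro on a bromoacrylamide aryl

The source may report more compounds than this note shows. Statements on the series, on what has been measured and on what is new or still open speak of the compounds shown alone.

Measured so far:
compound 1, `C=C(Br)C(=O)Nc1cccc(-c2cn3nc(-c4ccc(OCC)cc4)sc3n2)c1`, 1100 nM
compound 2, `Nc1cccc(-c2cn3c(-c4ccc(Cl)cc4)csc3n2)c1`, 17000 nM

In a functional assay on HeLa cells (Homo sapiens) for inhibition, read by cell counting, with a stated time of 4 days (on this read-out lower numbers stand for stronger inhibition and higher numbers for weaker inhibition), compound 1 gives 1100 nM, the lower of the two numbers recorded. Differing from compound 1 in several places, compound 2 gives 17000 nM in this assay, a gap well beyond the usual scatter; with no single-point step between them, nothing more is drawn from that pair.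

The next compound, compound 3 `C=C(Br)C(=O)Nc1cccc(-c2cn3nc(-c4ccc(F)cc4)sc3n2)c1`, keeps the core and the bromoacrylamide of compound 1 and changes one group: fluoro in place of ethoxy on an aromatic carbon. An ethoxy group gives way to a fluoro on the same aromatic carbon of the six-membered carbon-only ring.

Nothing measured here shows how this position responds, so a modest step is expected, likely a slight weakening, with a 1.5-fold higher number from compound 1 to compound 3 (0.16 log units; within the scatter) for compound 3. In this assay compound 3 is estimated at 1600 nM, within 500 nM to 5000 nM.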

Compound 3, half-maximal inhibitory concentration: 870 nM
Compound 3: middle estimate off by 1.8-fold (0.26 log units), on the high side; the range from low to high includes it.
By their numbers in this assay, from the lowest: compounds 3 and 1 (each within the scatter of the next); then compound 2.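

In this assay, going by these compounds alone, the exchange of 4-ethoxyphenyl for 4-fluorophenyl gives a 1.3-fold lower number from compound 1 to compound 3 (0.10 log units; within the scatter), the first single-place comparison in this set. At this aromatic carbon, para to a large group, ethoxy and fluoro therefore cannot be told apart on this read-out, even though the two groups differ in heavy-atom count and in hydrogen-bond acceptors. Nothing available here explains this lack of separation.

Going by these compounds, two groups cannot define how this position responds in general, so it remains open whether a carboxylic acid, an amine or a longer alkoxy chain would read the same way. Within the data shown here, the contribution of the bromoacrylamide also remains open, since compound 2 differs from compound 1 in several places and no single-place step isolates that group.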